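A few compounds are considered here, and "the series" means these few. Any claim that something is new, unique, unknown or untested is made for them only; others in the source may bear on it.

Measured in an ADME assay on MT4 cells (Homo sapiens) for cytotoxicity, with a stated time of 5 days; on this read-out higher numbers stand for lower toxicity in this test and lower numbers for higher toxicity in this test (both values are limits of the assay):
- compound 1 `CC(C)(C)C#Cc1cc(N(C(=O)[C@H]2CC[C@H](C)CC2)[C@H]2CC[C@H](OC3COC3)CC2)c(C(=O)O)s1`: > 20000 nM
- compound 2 `CC(C)(C)C#Cc1cc(N(C(=O)[C@H]2CC[C@H](C)CC2)[C@H]2CC[C@H](Oc3ccncn3)CC2)c(C(=O)O)s1`: > 20000 nM

Compound 2 gives > 20000 nM, which is a limit and not a number. For the measured compounds named here, the series so far shows (the limit of > 20000 nM in this assay, at which 2 of the 2 values shown sit), so compound 2 has no measured number to build on.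

The next analogue is compound 3 `CC(C)(C)C#Cc1cc(N(C(=O)[C@H]2CC[C@H](C)CC2)[C@H]2CC[C@H](Oc3nccs3)CC2)c(C(=O)O)s1`, which keeps the shared core and changes only the group on the oxygen: 1,3-thiazol-2-yl in place of pyrimidin-4-yl on an oxygen on a saturated carbon. In words, 1,3-thiazol-2-yl stands in place of pyrimidin-4-yl on an oxygen on a saturated carbon.

Going by the values given here, the one measured step that bears on this position is a step that the two limits leave unreadable from compound 1 to compound 2. It replaced oxetan-3-yl with pyrimidin-4-yl at the same place, and it has no readable size. No step beyond the scatter is therefore expected in this assay, and no direction can be assigned. Compound 3 is expected to be reported most likely as a limit again.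

The expected step is a number no higher from compound 2 to compound 3 (the limit leaves the size open), and this is an estimate only. For compound 3 the estimated value is 20000 nM, with an expected range from 10000 nM to 30000 nM.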

Compound 3, half-maximal cytotoxic concentration: > 20000 nM
Compound 3: only a limit was reported; the forecaster's own chance of this, stated with the estimate: 80%; the middle value sits exactly at the limit.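

In this assay compound 3 gives > 20000 nM as a limit of the assay and not a number. No new step can be read among compound 1, compound 2 and compound 3, which all share one limit: the limit of > 20000 nM in this assay, at which 3 of the 3 values shown sit.

The compounds shown leave open how far the three differ in this read-out, and whether any group on the oxygen gives a measured number.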